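Benzyloxy Coumarin Amides Against Monoamine Oxidase A

This account rests on a few compounds, and the source may have more. Where it says the series, first, only, none or still open, it means among the compounds named here.

Measured so far:
compound 1, `NC(=O)[C@@H]1CCCN1c1cc(=O)oc2cc(OCc3ccccc3)ccc12`, 99800 nM
compound 2, `NC(=O)[C@H](CO)Nc1cc(=O)oc2cc(OCc3cccc(Cl)c3)ccc12`, > 100000 nM
compound 3, `NNC(=O)Cc1cc(=O)oc2cc(OCc3cccc(Cl)c3)ccc12`, 2500 nM

In an assay (strain Wistar) for inhibition of Amine oxidase [flavin-containing] A (Rattus norvegicus) (on this read-out higher numbers stand for weaker inhibition and lower numbers for stronger inhibition), compound 1 gives 99800 nM, the highest of the two numbers reported. Compound 2 reaches only the limit of the limit of > 100000 nM in this assay, at which 1 of the 3 values shown sits, so it carries no number. Among the measured compounds shown here, compound 3 gives 2500 nM, and the one step that can be computed, an at least 40-fold lower number from compound 2 to compound 3 (1.60 log units; beyond the scatter), is the only guide to how changes at this position of the core behave.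

Compound 4, `CC(C(N)=O)c1cc(=O)oc2cc(OCc3ccccc3)ccc12`, is not yet measured. It differs from compound 1 by 1-carbamoylethyl in place of 2-carbamoylpyrrolidin-1-yl on an aromatic carbon. As in compound 3, the group in compound 4 is joined to the core through a carbon rather than a nitrogen, and it is acyclic and small, whereas compound 1 carries its amide on a ring attached through nitrogen. The large step of an at least 40-fold lower number from compound 2 to compound 3 (1.60 log units; beyond the scatter) points the same way: moving from a nitrogen-linked amide to a carbon-linked amide-type chain gave a much lower number. Compound 4 is therefore expected to sit well below compound 1, though the benzyloxy group of compound 1 is kept and the hydrazide of compound 3 is not. The expected step is a 6.7-fold lower number from compound 1 to compound 4 (0.82 log units; beyond the scatter). The estimate for compound 4 is 15000 nM, with a range from 2500 nM to 90000 nM.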

Compound 4, half-maximal inhibitory concentration: 6260 nM
Compound 4: the middle estimate sits 2.4-fold (0.38 log units) above what was measured, and the stated range covers the measured number.
By their numbers in this assay, from the lowest: compound 3; then compound 4; then compound 1. At a limit, above all of these: compound 2.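

In this assay, among the compounds shown here, replacing the group opposite the ring oxygen gives a 16-fold lower number from compound 1 to compound 4 (1.20 log units; beyond the scatter), and this is the first step at this position that runs between two actual numbers. The earlier step started from a limit, not a number, in compound 2: the limit of > 100000 nM in this assay, at which 1 of the 4 values shown sits. Both compound 1 and compound 4 carry a carbamoyl group and share the benzyloxy group, so the presence of the amide alone does not set the number at this position, and the large change comes with the loss of the pyrrolidine ring and of the nitrogen link to the core.

These two changes arrive together in compound 4, so the compounds shown cannot say which of them matters, and an open-chain 1-carbamoylethylamino group or a pyrrolidine joined to the core through carbon would be needed to separate them. From the compounds shown here alone, it also remains open whether the amide itself is needed on the carbon-linked chain, which a carboxylic acid or a primary amine in its place would test, and whether a 3-chlorobenzyloxy group would shift the number for compound 4.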